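The source may report more compounds than this note shows. Statements on the series, on what has been measured and on what is new or still open speak of the compounds shown alone.

Among the compounds with values here, compound 2 `C[C@H]1[C@H](NCc2cc(C3CC3)cs2)C[C@H]2C[C@@H]1C2(C)C` holds the highest of the two numbers measured so far in an ADME assay on MDCK cells (Canis lupus familiaris) for cytotoxicity, read by microscopy, with a stated time of 48 h (a higher number here means that more compound is tolerated, a lower number that less compound is tolerated), where compound 2 gives 25000 nM. Within the data shown here, its only neighbour, compound 1 `CCc1ccc(CN[C@@H]2C[C@H]3C[C@@H]([C@H]2C)C3(C)C)s1`, gives 1560 nM in this assay, and that gap lies beyond the scatter. Compound 3 `C[C@H]1[C@H](NCc2cc(Br)cs2)C[C@H]2C[C@@H]1C2(C)C` carries one change from compound 2: bromo in place of cyclopropyl on an aromatic carbon. Among the measured compounds shown here, no measured pair shows this change, so its effect is unknown. The step from compound 2 to compound 3 is expected to be a modest fall, a 3.1-fold lower number from compound 2 to compound 3 (0.49 log units; beyond the scatter). Compound 3 is therefore estimated at 8000 nM, with a range from 2000 nM to 30000 nM.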

Compound 3, minimum cytotoxic concentration: 6250 nM
For compound 3 the middle estimate is 1.3-fold (0.11 log units) above the measured one, within the range that was stated.
By their numbers in this assay, from the lowest: compound 1; then compound 3; then compound 2.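

Replacing cyclopropyl with bromo on this carbon of the five-membered aromatic ring gives, in this assay, a 4.0-fold lower number from compound 2 to compound 3 (0.60 log units; beyond the scatter). Within the data shown here, this is the first comparison in which only one place differs, so it shows that the group at this ring carbon can by itself shift the tolerated concentration beyond the scatter. Nothing available explains the shift. From the compounds shown here alone, how an amine or a carboxylic acid at this carbon would compare remains open. So does whether the same swap gives a similar step on another core.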